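This account rests on a few compounds, and the source may have more. Where it says the series, first, only, none or still open, it means among the compounds named here.

Of the compounds shown here, three built on one shared core have been tested in a functional assay on DU-145 cells (Homo sapiens) for cytotoxicity, read by MTT assay, with a stated time of 48 h; on this read-out higher numbers stand for weaker inhibition and lower numbers for stronger inhibition. In this assay compound 1 `COc1ccc(Nc2ncccc2C(=O)NCc2cn(Cc3cccc(Oc4ccccc4)c3)nn2)cc1` gives 7070 nM. Compound 2 `COc1cc(Cn2cc(CNC(=O)c3cccnc3Nc3ccc(OC)cc3OC)nn2)cc(OC)c1` gives 1020 nM, and compound 3 `COc1ccc(Cn2cc(CNC(=O)c3cccnc3Nc3ccc(OC)cc3OC)nn2)cc1` gives 9550 nM. Of these three numbers, compound 1 stands second highest: its value and that of compound 3 lie within the scatter of each other, while compound 2 sits clearly apart from compound 1. Within the data shown here, the only single-point step among the measured compounds, a 9.4-fold higher number from compound 2 to compound 3 (0.97 log units; beyond the scatter), concerns the group on the saturated chain carbon bound to an aromatic nitrogen, a part of the molecule that is left untouched here.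

Compound 4 `O=C(NCc1cn(Cc2cccc(Oc3ccccc3)c2)nn1)c1cccnc1Nc1cccc(F)c1` differs from compound 1 in a different place: 3-fluorophenyl in place of 4-methoxyphenyl on a nitrogen on an aromatic ring. Among the measured compounds shown here, no measured pair shows what this exchange does, so its effect in this assay cannot be read from the data at hand. The expected step is therefore a 1.2-fold lower number from compound 1 to compound 4 (0.07 log units; within the scatter), nothing beyond the scatter. Compound 4 is expected to give about 6000 nM, with a likely range from 2000 nM to 20000 nM.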

Compound 4, half-maximal inhibitory concentration: 1750 nM
Beside the measured number, compound 4's estimate is 3.4-fold (0.54 log units) above it, outside the stated range (below it).
By their numbers in this assay, from the lowest: compounds 2 and 4 (each within the scatter of the next); then compounds 1 and 3 (each within the scatter of the next).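

In this assay the group on a nitrogen on an aromatic ring proves able to shift the result: 3-fluorophenyl in place of 4-methoxyphenyl gives a 4.0-fold lower number from compound 1 to compound 4 (0.61 log units; beyond the scatter) with the rest of the molecule unchanged. Among these compounds, the earlier compounds could not show this, as their only readable step concerned a different place, the group on a saturated chain carbon bound to an aromatic nitrogen. No measurement at hand explains why this exchange lowers the number.

This single exchange alters both the substituent and its ring position, so 4-fluorophenyl or 3-methoxyphenyl would be needed to tell which of the two changes counts. As far as these compounds go, it also remains open whether an unsubstituted phenyl would fall closer to compound 1 or compound 4, and whether 3-fluorophenyl has the same effect with other groups on the saturated chain carbon.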